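Larger alkyl group on the weak methoxy analogue

A few compounds are considered here, and "the series" means these few. Any claim that something is new, unique, unknown or untested is made for them only; others in the source may bear on it.

Of the compounds shown here, three have been measured in a functional assay on the whole organism with Rattus norvegicus as the target, at a dose of 1 mg/kg by the oral route; a higher number here means a stronger effect of the compound at the dose given, a lower number a weaker effect.
Compound 1 `Cc1ccc(-c2cc(Cl)cc(C(=O)Nc3nn[nH]n3)n2)cc1` gives 86%.
Compound 2 `CCCc1ccc(-c2cc(Cl)cc(C(=O)Nc3nn[nH]n3)n2)cc1` gives 78%.
Compound 3 `COc1cc(C(=O)Nc2nn[nH]n2)nc(-c2ccc(C)cc2)c1` gives 42%.

Compound 3 stands lowest of the three, below compound 2 and compound 1, the latter by a number 44 percentage points lower from compound 1 to compound 3 (beyond the scatter).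

Compound 4 `COc1cc(C(=O)Nc2nn[nH]n2)nc(-c2ccc(C(C)C)cc2)c1` differs from compound 3 as follows: isopropyl in place of methyl on an aromatic carbon. Among the compounds with values here, the only measured step that bears on this change is a number 8 percentage points lower from compound 1 to compound 2 (within the scatter), where enlarging the same alkyl group shifted the read-out by little. The change to compound 4 is therefore expected to move the number by about a number 4 percentage points lower from compound 3 to compound 4 (within the scatter), which is no step beyond the scatter. Compound 4 is estimated to give 38%, within a range from 20% to 58%.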

Compound 4, a percentage reported as inhibition, in the whole organism at one dose (the size of the read-out at that dose, not a potency): 54%
Estimate against measurement, compound 4: 16 percentage points below, within the range that was stated.
By their numbers in this assay, from the lowest: compound 3; then compound 4; then compounds 2 and 1 (each within the scatter of the next).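

In this assay, the alkyl group on this aromatic carbon can matter: isopropyl in place of methyl gives a number 12 percentage points higher from compound 3 to compound 4 (beyond the scatter), a modest rise. The earlier enlargement, with chloro on the core and a different pair of alkyl groups, gave a number 8 percentage points lower from compound 1 to compound 2 (within the scatter), so the methoxy compounds show an effect that the chloro pair did not. Nothing available explains this rise.

From the compounds shown here alone, it remains open whether a longer chain such as butyl at this place would raise the number further. Going by these compounds, it is also open whether isopropyl would give a similar step with chloro in place of methoxy.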